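Cytotoxicity Limits and a Trifluoromethoxy Swap on the Shared Core

The compounds below may be only part of what the source reports. "The series", "measured", "known", "first", "only" and "open" are said of these compounds alone.

In an ADME assay on CHO cells (Cricetulus griseus) for cytotoxicity, read by MTT assay, with a stated time of 24 h (on this read-out lower numbers stand for higher toxicity in this test and higher numbers for lower toxicity in this test), compound 1 (`CC1Cn2c(nc([N+](=O)[O-])c2-c2ccc(Cl)cc2)O1`) gives only a limit of > 250000 nM and no number. In this assay compound 2 (`CC1Cn2c(nc([N+](=O)[O-])c2-c2cccc(C#N)c2)O1`) likewise gives only a limit of > 500000 nM and no number. Going by the values given here, compound 1 therefore stands on a limit, and no measured step is available to size a change on this core.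

Compound 3 (`CC1Cn2c(nc([N+](=O)[O-])c2-c2ccc(OC(F)(F)F)cc2)O1`) is still unmeasured. It carries trifluoromethoxy in place of chloro on an aromatic carbon, para to a large group (trifluoromethoxy in place of chloro on an aromatic carbon), and keeps the core of compound 1.

In this assay no step beyond the usual scatter is expected in either direction. This expectation rests on compound 1 and its limit of > 250000 nM as the only close reference. The estimated step that the limit leaves unreadable from compound 1 to compound 3 is correspondingly small. For compound 3 the expected value is 300000 nM with an estimated range from 120000 nM to 600000 nM and a report as a limit is likely.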

Compound 3, half-maximal cytotoxic concentration: > 125000 nM
Compound 3 ended at the assay's limit; the forecaster's own chance of this, stated with the estimate: 75%; the middle value is on the limit's open side.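

Going by these compounds alone, compound 1 and compound 3 both stand on limits in this assay, and no step between them can be read. The compounds shown leave open whether trifluoromethoxy in place of chloro on an aromatic carbon changes this read-out at all, and in which direction.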